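The source may report more compounds than this note shows. Statements on the series, on what has been measured and on what is new or still open speak of the compounds shown alone.

Measured so far in a functional assay on MCF7 cells (Homo sapiens) for inhibition, read by MTT assay, with a stated time of 2 days; a lower number here means a stronger inhibitor, a higher number a weaker inhibitor:
- compound 1, `Oc1cccc(/C=C/c2cccc(O)c2)c1`: 21 ug/mL
- compound 2, `Nc1cccc(/C=C/c2cccc(O)c2)c1`: 54 ug/mL
- compound 3, `COc1ccc(/C=C/c2cccc(O)c2)cc1`: 21 ug/mL

Compound 4, `COc1ccc(/C=C/c2cccc(N)c2)cc1`, is not yet measured in this assay.

Within the measured set, the one counted step is amino in place of hydroxy on an aromatic carbon, which gave a 2.6-fold higher number from compound 1 to compound 2 (0.41 log units; beyond the scatter). Compound 3 stands level with compound 1 at the digits shown, the two together at the low end of the three numbers.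

The difference between the core of compound 3 and the core of compound 1 is not broken down here.

Compound 4 carries the same kind of change relative to compound 3, (amino in place of hydroxy on an aromatic carbon); the place descriptions are not identical, the group sitting meta to a large group in one case and meta to a group of 9 heavy atoms in the other.

For the measured compounds named here, the expected step is a 2.6-fold higher number from compound 3 to compound 4 (0.42 log units; beyond the scatter), resting on the single precedent a 2.6-fold higher number from compound 1 to compound 2 (0.41 log units; beyond the scatter). For compound 4 the estimate in this assay is 55 ug/mL, within roughly 30 ug/mL to 100 ug/mL.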

Compound 4, half-maximal inhibitory concentration: 23 ug/mL
Compound 4: middle estimate off by 2.4-fold (0.38 log units), on the high side; the whole stated range lies above it.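

In this assay, amino in place of hydroxy on an aromatic carbon gives a 1.1-fold higher number from compound 3 to compound 4 (0.04 log units; within the scatter). Set beside the earlier step, the two cannot be told apart: the same change on two cores in this assay, a 2.6-fold higher number (0.41 log units; beyond the scatter) from compound 1 to compound 2 and a 1.1-fold higher number (0.04 log units; within the scatter) from compound 3 to compound 4, 2.3-fold (0.37 log units) apart, within the scatter of two such steps The change can therefore be carried between these two cores without a detectable difference in step size, but this does not establish a fixed step, as only one of the two steps lies beyond the scatter and two steps are a thin basis.

The compounds shown leave open how the same change behaves on any other core. They also leave open what other groups at this place, such as a carboxylic acid or a nitrile, would give.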